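Solubility notes on compounds 1, 2 and 3

The source may report more compounds than this note shows. Statements on the series, on what has been measured and on what is new or still open speak of the compounds shown alone.

Compound 1, `OC1CCN(c2nccnc2OC2CN(c3ccc4ccccc4n3)C2)CC1`: in a physicochemical assay for solubility, in phosphate buffer, at pH 7.4 (a higher number here means a more soluble compound, a lower number a less soluble compound), compound 1 gives 99000 nM.
Compound 2, `c1ccc(-c2nccnc2OC2CN(c3ccc4ccccc4n3)C2)cc1`: in this assay compound 2 gives < 1000 nM, which is a limit of the assay and not a number.

Within the data shown here, compound 1 holds the only number; the other value is a limit. Among the measured compounds shown here, the one measured step, an at least 99-fold lower number from compound 1 to compound 2 (1.99 log units; beyond the scatter), runs down to the limit of < 1000 nM in this assay, at which 1 of the 2 values shown sits. Compound 3, `c1ccc(-c2nccnc2OC2CN(c3ccc4ccccc4n3)C2)nc1`, differs from compound 1 as follows: pyridin-2-yl in place of 4-hydroxypiperidin-1-yl on an aromatic carbon. As in the step to compound 2, 4-hydroxypiperidin-1-yl with its 1 hydrogen-bond donor leaves and a six-membered aromatic ring enters, here one with 1 hetero atom and 1 hydrogen-bond acceptor. For the measured compounds named here, that measured step is the only guide, and it was large and downward. A downward step is therefore expected in this assay, a 40-fold lower number from compound 1 to compound 3 (1.60 log units; beyond the scatter), possibly smaller than the measured one. Compound 3 is estimated at 2500 nM, with a range of 500 nM to 12000 nM.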

Compound 3, solubility: 349000 nM
Compound 3: the middle estimate sits 140-fold (2.14 log units) below what was measured; measured number above the stated range.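

At this position, a six-membered aromatic ring with 0 hydrogen-bond donors does not have to bring the number down in this assay: pyridin-2-yl gives a 3.5-fold higher number from compound 1 to compound 3 (0.55 log units; beyond the scatter), against the direction of the earlier step. The exchange between the two aromatic rings alone gives an at least 340-fold higher number from compound 2 to compound 3 (2.54 log units; beyond the scatter), so in these compounds the outcome depends on which aromatic ring enters, and the departure of 4-hydroxypiperidin-1-yl does not settle it. The size of that step is only a bound, as compound 2 rests on a limit of the assay and not a number: the limit of < 1000 nM in this assay, at which 1 of the 3 values shown sits.

The compounds shown do not tell whether the ring nitrogen must sit where pyridin-2-yl places it, a question that pyridin-3-yl or pyridin-4-yl would address. They also leave open how a phenyl ring carrying an amine or a carboxylic acid would read at this position.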